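The source may report more compounds than this note shows. Statements on the series, on what has been measured and on what is new or still open speak of the compounds shown alone.

Of the compounds shown here, two with a shared core have been tested so far. In a functional assay on MCF7 cells (Homo sapiens) for antiproliferative activity, read by MTT assay, with a stated time of 72 h (a lower number here means a stronger inhibitor, a higher number a weaker inhibitor), compound 1 `O=C1COc2ccc(-c3cnc(Cl)c(NS(=O)(=O)c4ccc(F)cc4)c3)cc2N1c1ccc(F)cc1` gives 32600 nM, and compound 2 `O=C1COc2ccc(-c3cccc(NS(=O)(=O)c4ccc(F)cc4)c3)cc2N1c1ccc(Cl)cc1` gives 39800 nM. The number for compound 2 is the higher of the two, yet the gap to compound 1 lies within the scatter, so the two read as alike. Compound 3 `O=C1COc2ccc(-c3cccc(NS(=O)(=O)c4ccc(F)cc4)c3)cc2N1C1CCCCC1` differs from compound 2 by cyclohexyl in place of 4-chlorophenyl on an amide-type nitrogen in a ring. Going by the values given here, with no measured step of this kind to lean on, the change from compound 2 to compound 3 is expected to move this assay only a little, if at all, in either direction; the step of a 1.1-fold higher number from compound 2 to compound 3 (0.05 log units; within the scatter) is an estimate. Compound 3 is therefore expected to give about 45000 nM, between 15000 nM and 130000 nM.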

Compound 3, half-maximal inhibitory concentration: 21400 nM
The estimate for compound 3 lay 2.1-fold (0.32 log units) above the measured number; measured number inside the range.
By their numbers in this assay, from the lowest: compounds 3, 1 and 2 (each within the scatter of the next).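

In this assay, cyclohexyl in place of 4-chlorophenyl on the amide-type nitrogen in a ring gives a 1.9-fold lower number from compound 2 to compound 3 (0.27 log units; within the scatter) and so leaves the number within the scatter. For this pair, then, the nitrogen can carry a non-aromatic ring of carbon as well as a chlorine-bearing aromatic one with no clear difference in the read-out. Nothing measured here gives a reason for this result.

From the compounds shown here alone, whether a longer chain, or a cyclohexyl ring carrying an amine or a carboxylic acid, would move the number beyond the scatter remains open. So does whether the same swap would read alike on the core of compound 1.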